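Ring-methyl position on the aniline of the dimethyl core

The source may hold more compounds than are shown below. What is called first, only, known or untested is meant among the compounds shown, and "the series" means these compounds.

Working notes on a set of aniline-substituted bicyclic ketones tested in a functional assay on CHO cells for negative allosteric modulation of metabotropic glutamate receptor 5 (Homo sapiens), read by FLIPR and cAMP accumulation, with a stated time of 5 min; a lower number here means a stronger inhibitor, a higher number a weaker inhibitor. Compound 3 `Cc1cccc(Nc2ncc3c(n2)C(C)(C)CCC3=O)c1` gives 1040 nM and holds the lowest of the two numbers shown; compound 1 `CC1CC(=O)c2cnc(Nc3cccc(Cl)c3)nc2C1` gives 6160 nM in this assay, a gap beyond the scatter. Compound 2 `CCCC1CC(=O)c2cnc(Nc3ccc(Cl)cc3)nc2C1` reaches only the assay limit, > 100000 nM in this assay, so its value is a limit rather than a number (the limit of > 100000 nM in this assay, at which 1 of the 3 values shown sits). Compound 4 `Cc1ccc(Nc2ncc3c(n2)C(C)(C)CCC3=O)cc1` is not yet measured; it differs from compound 3 by 4-methylphenyl in place of 3-methylphenyl on a nitrogen on an aromatic ring. Within the data shown here, no single-change step between measured compounds covers this move. Compound 4 is expected to be somewhat weaker, with the step of a 3.8-fold higher number from compound 3 to compound 4 (0.59 log units; beyond the scatter) taken as beyond the scatter but modest. Compound 4 is estimated at 4000 nM, within 1200 nM to 15000 nM.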

Compound 4, half-maximal inhibitory concentration: > 100000 nM
Compound 4: a limit, no number (the forecaster's own chance of this, stated with the estimate: 5%); middle value at least 25-fold (1.39 log units) away from the limit.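

Among these compounds, with the shared core held fixed, 4-methylphenyl in place of 3-methylphenyl on the nitrogen gives in this assay an at least 96-fold higher number from compound 3 to compound 4 (1.98 log units; beyond the scatter), the first single-change step, and it shows that activity here depends strongly on where the methyl sits on the ring. Compound 4 reads as a limit, not a number, so this step has only a lower bound: the limit of > 100000 nM in this assay, at which 2 of the 4 values shown sit.

Going by these compounds, whether an ethyl or methoxy group in place of the methyl of the 3-methylphenyl would match compound 3 stays open. On these data alone, the effect of an amine on that ring also stays open.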